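Swapping a methylphenyl amide for a chloropyridinyl amide

The compounds below may be only part of what the source reports. "The series", "measured", "known", "first", "only" and "open" are said of these compounds alone.

The measured compounds and their values:
compound 1, `COc1ccc(C(=O)Nc2ccc3nc(NC(=O)C4CCCCC4)sc3c2)cc1`, gives 4.9 ug/mL;
compound 2, `Cc1ccc(C(=O)Nc2ccc3nc(NC(=O)C4CCCCC4)sc3c2)cc1`, gives 5.1 ug/mL.

Both numbers come from a functional assay on WI-38 VA13 cells (Homo sapiens) for cytotoxicity; a lower number here means that less compound is needed, a higher number that more compound is needed for the effect. Compound 2 and compound 1 differ only by a methyl in place of a methoxy on an aromatic carbon, and the step of a 1.0-fold higher number from compound 1 to compound 2 (0.02 log units; within the scatter) shows that this exchange left the read-out essentially unchanged, so compound 2 stands together with compound 1 rather than apart from it.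

Compound 3, `O=C(Nc1ccc2nc(NC(=O)C3CCCCC3)sc2c1)c1cccnc1Cl`, has not yet been measured in this assay. It differs from compound 2 by 2-chloropyridin-3-yl in place of 4-methylphenyl on a carbonyl carbon. For the measured compounds named here, no measured step touches the same kind of exchange: the only step known, from compound 1 to compound 2, swaps one small group for another on the same aromatic ring and stays within the scatter. Replacing the whole aromatic ring by a ring containing nitrogen and chlorine is a larger change, but nothing measured points in either direction.

The number expected for compound 3 is therefore close to that of compound 2, with a step of a 1.0-fold lower number from compound 2 to compound 3 (0.01 log units; within the scatter), and the estimate is 5 ug/mL, with a likely range from 2 ug/mL to 12.5 ug/mL.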

Compound 3, half-maximal effective concentration: 0.075 ug/mL
Compound 3: the middle estimate sits 67-fold (1.82 log units) above what was measured; the measured number lies below the stated range.
By their numbers in this assay, from the lowest: compound 3; then compounds 1 and 2 (each within the scatter of the next).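

In this assay, the group on the carbonyl carbon proves to matter a great deal: 2-chloropyridin-3-yl in place of 4-methylphenyl gives a 68-fold lower number from compound 2 to compound 3 (1.83 log units; beyond the scatter), and the same group in place of 4-methoxyphenyl gives a 65-fold lower number from compound 1 to compound 3 (1.82 log units; beyond the scatter), so far less compound is needed for the effect. The earlier pair showed only that methyl and methoxy could be exchanged on the phenyl ring without a step beyond the scatter, whereas replacing the ring itself shows that this position does respond strongly to at least one change. Nothing at hand explains why this exchange has so large an effect.

The ring nitrogen and the chlorine enter together, so the compounds shown leave open whether one of them alone accounts for the step, a question that a phenyl ring carrying chlorine and a pyridine ring without chlorine could settle. Also open, on these data alone, is how much of the step survives when the chlorine gives way to another group on the same pyridine ring, such as an amine or a methyl.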